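Swapping the Amide Aryl Group for Pyridine

The source may report more compounds than this note shows. Statements on the series, on what has been measured and on what is new or still open speak of the compounds shown alone.

Compound 1 `CC(=O)N1CCC[C@H]1C(=O)N1CCC(NS(=O)(=O)c2cc(S(=O)(=O)c3ccccc3)ccc2C(F)(F)F)CC1` gives 160 nM in an assay on isolated protein for binding affinity to secreted frizzled-related protein 1 (Homo sapiens), read by fluorescence; a lower number here means a stronger inhibitor, a higher number a weaker inhibitor. Compound 2 `CC(C)(C)CC(=O)N1CCC[C@H]1C(=O)N1CCC(NS(=O)(=O)c2cc(S(=O)(=O)c3ccccc3)ccc2C(F)(F)F)CC1` gives 20 nM, and compound 3 `CN(C)c1ccc(C(=O)N2CCC[C@H]2C(=O)N2CCC(NS(=O)(=O)c3cc(S(=O)(=O)c4ccccc4)ccc3C(F)(F)F)CC2)cc1` gives 110 nM, the second highest of the three numbers. The step of a 1.5-fold lower number from compound 1 to compound 3 (0.16 log units; within the scatter) lies within the scatter, whereas an 8.0-fold lower number from compound 1 to compound 2 (0.90 log units; beyond the scatter) and a 5.5-fold higher number from compound 2 to compound 3 (0.74 log units; beyond the scatter) are modest. Compound 4 `O=C([C@@H]1CCCN1C(=O)c1ccncc1)N1CCC(NS(=O)(=O)c2cc(S(=O)(=O)c3ccccc3)ccc2C(F)(F)F)CC1` differs from compound 3 by pyridin-4-yl in place of 4-(dimethylamino)phenyl on a carbonyl carbon. Among the compounds with values here, no measured step shares this exact change; the only variation seen at this carbonyl carbon, a 1.5-fold lower number from compound 1 to compound 3 (0.16 log units; within the scatter), stayed within the scatter, so in this assay a step of no more than modest size is expected, most likely none beyond the scatter. For compound 4 the estimate in this assay is 150 nM, with a range from 60 nM to 400 nM, which is expected to correspond to the step of a 1.4-fold higher number from compound 3 to compound 4 (0.13 log units; within the scatter).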

Compound 4, half-maximal inhibitory concentration: 70 nM
For compound 4 the middle estimate is 2.1-fold (0.33 log units) above the measured one; measured number inside the range.
By their numbers in this assay, from the lowest: compound 2; then compounds 4, 3 and 1 (each within the scatter of the next, the first and the last beyond it).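

In this assay, pyridin-4-yl on this carbonyl carbon performs on a par with 4-(dimethylamino)phenyl (a 1.6-fold lower number from compound 3 to compound 4 (0.20 log units; within the scatter)), a step that stays within the scatter despite the smaller group. Against methyl, the new group gives a separation beyond the scatter (a 2.3-fold lower number from compound 1 to compound 4 (0.36 log units; beyond the scatter)), which 4-(dimethylamino)phenyl did not, while neopentyl still keeps the lowest number (a 3.5-fold higher number from compound 2 to compound 4 (0.54 log units; beyond the scatter)).

On these data alone, whether a carboxylic acid, a primary amine or a longer branched alkyl chain on this carbonyl carbon would match neopentyl remains open. Nothing available explains these differences.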